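A few compounds are considered here, and "the series" means these few. Any claim that something is new, unique, unknown or untested is made for them only; others in the source may bear on it.

In an assay for inhibition of histone-lysine N-methyltransferase EZH2 variant Y641N (Homo sapiens), read by scintillation counting, with a stated time of 60 min, in the presence of a further agent that is not named here (on this read-out lower numbers stand for stronger inhibition and higher numbers for weaker inhibition), compound 2 `Cc1cc(C)c(CN2CCc3c(Cl)cc([C@@H](CO)[C@@H]4CCCO4)c(Cl)c3C2=O)c(=O)[nH]1` gives 135 nM, the lower of the two single numbers shown. Compound 1 `Cc1cc(C)c(CN2CCc3c(Cl)cc([C@@H](CO)[C@@H]4CCOC4)c(Cl)c3C2=O)c(=O)[nH]1` gives 1260 nM, and compound 3 `COC(c1cc(Cl)c2c(c1Cl)C(=O)N(Cc1c(C)cc(C)[nH]c1=O)CC2)C1CCOCC1` gives 310 nM; 0.1 nM (2 entries), two entries far apart (the several entries of compound 3 in this assay, 310 nM; 0.1 nM (2 entries)). Among the compounds with values here, the one measured step that changes a single place, a 9.3-fold lower number from compound 1 to compound 2 (0.97 log units; beyond the scatter), comes from exchanging oxolan-3-yl for oxolan-2-yl and lies well beyond the scatter. Compound 4 `Cc1cc(C)c(CN2CCc3c(Cl)cc([C@@H](C)CO)c(Cl)c3C2=O)c(=O)[nH]1` removes that ring entirely: a group of 4 heavy atoms (3 carbon, 1 oxygen; no ring) in place of a group of 8 heavy atoms (6 carbon, 2 oxygen; one five-membered non-aromatic ring with 1 hetero atom), on an aromatic carbon. Within the data shown here, no measured step removes the ring, so the expectation rests only indirectly on the step of a 9.3-fold lower number from compound 1 to compound 2 (0.97 log units; beyond the scatter), which shows the ring region matters. Compound 4 is therefore expected to give a higher number, estimated at 700 nM, within 200 nM to 2500 nM. The expected step is a 5.2-fold higher number from compound 2 to compound 4 (0.71 log units; beyond the scatter).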

Compound 4, inhibition constant: 260 nM
For compound 4 the middle estimate is 2.7-fold (0.43 log units) above the measured one; low and high end bracket the measured number.
By their numbers in this assay, from the lowest: compounds 2 and 4 (each within the scatter of the next); then compound 1.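

In this assay, the step of a 1.9-fold higher number from compound 2 to compound 4 (0.28 log units; within the scatter) shows that the five-membered ring can be replaced by the open 1-(hydroxymethyl)ethyl group on this aromatic carbon without a change beyond the scatter. The step of a 4.8-fold lower number from compound 1 to compound 4 (0.69 log units; beyond the scatter) shows that the chain without a ring also reads better than the oxolan-3-yl compound. A ring is therefore not required at this position, and oxolan-3-yl is the poorer of the two rings.

Nothing given here explains why oxolan-3-yl fares worse. Going by these compounds, how a longer chain, or an amine in place of the hydroxyl group, would read at this position remains open.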